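Extending a Saturated Chain Once More

The compounds below may be only part of what the source reports. "The series", "measured", "known", "first", "only" and "open" are said of these compounds alone.

In a functional assay on OVCAR-5 cells (Homo sapiens) for inhibition, with a stated time of 48 h, tested at 50 uM (on this read-out higher numbers stand for more inhibition of growth at the one concentration tested and lower numbers for less inhibition of growth), compound 1 `C=C[C@@](C)(/C=C/c1ccc(OC(=O)CC)cc1)CCC=C(C)C` gives 52%, while compound 2 `C=C[C@@](C)(/C=C/c1ccc(OC(=O)CCC)cc1)CCC=C(C)C` gives 41%. For the measured compounds named here, compound 2 therefore holds the lower of the two numbers so far, and the gap between them lies beyond the usual scatter.

The next structure, compound 3 `C=C[C@@](C)(/C=C/c1ccc(OC(=O)CCCC)cc1)CCC=C(C)C`, differs from compound 2 in one place: methyl in place of hydrogen on a saturated chain carbon, three bonds along the chain from a carbonyl carbon. This is methyl in place of hydrogen on a saturated chain carbon, three bonds along the chain from a carbonyl carbon, which can also be read as propyl to butyl.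

Going by the values given here, one measured step bears on this change: a number 11 percentage points lower from compound 1 to compound 2 (beyond the scatter). It is a modest step, made by the same replacement, there two bonds along the chain from a carbonyl carbon. A single step cannot establish a trend, so nothing guarantees that the decline continues. Even so, the expected result is a number 8 percentage points lower from compound 2 to compound 3 (within the scatter), another drop but probably a smaller one, near the edge of the scatter. For compound 3, the estimated value in this assay is 33%, with an expected range from 20% to 46%.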

Compound 3, percent growth inhibition at one concentration: 3%
For compound 3 the middle estimate is 30 percentage points above the measured one, and the stated range ends above it.
By their numbers in this assay, from the lowest: compound 3; then compound 2; then compound 1.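

Propyl to butyl, methyl in place of hydrogen on a saturated chain carbon, three bonds along the chain from a carbonyl carbon, adds a single carbon, yet in this assay it brings a number 38 percentage points lower from compound 2 to compound 3 (beyond the scatter), a large step where the same replacement two bonds along the chain had given only a modest one. Read as one change, the whole extension of the chain gives a number 49 percentage points lower from compound 1 to compound 3 (beyond the scatter), so across these three compounds growth inhibition does not fall by similar amounts with each added carbon but drops far more at the second addition. Nothing measured here explains why one more methyl makes so large a difference.

The compounds shown leave open whether a longer chain such as pentyl would stay as low as compound 3 or regain some inhibition, and whether a branched group such as isopropyl would behave like its straight-chain relatives. With only one concentration tested, they also leave open how these compounds would compare across a range of concentrations.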